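The compounds below may be only part of what the source reports. "The series", "measured", "known", "first", "only" and "open" are said of these compounds alone.

Compound 1 `OC[C@H]1O[C@@H](n2cnc3c(NCc4ccc(Br)cc4)ncnc32)[C@H](O)[C@@H]1O`: > 166000 nM
Compound 2 `Cc1cccc(CNc2ncnc3c2ncn3[C@@H]2O[C@H](CO)[C@@H](O)[C@H]2O)c1`: > 166000 nM
Compound 3 `COc1ccccc1CNc1ncnc2c1ncn2[C@@H]1O[C@H](CO)[C@@H](O)[C@H]1O`: > 166000 nM

All three values come from a functional assay on B16 cells (Mus musculus) for antiproliferative activity, with a stated time of 72 h; a lower number here means a stronger inhibitor, a higher number a weaker inhibitor. Each of them is a limit of the assay, not a measured number: compound 1, compound 2 and compound 3 all reach only the limit described by the limit of > 166000 nM in this assay, at which 3 of the 3 values shown sit. Compound 3 therefore stands at that limit, with nothing to set it apart from the other two, since the steps a step that the two limits leave unreadable from compound 1 to compound 2, a step that the two limits leave unreadable from compound 1 to compound 3 and a step that the two limits leave unreadable from compound 2 to compound 3 all remain unreadable between two limits.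

Compound 4 `OC[C@H]1O[C@@H](n2cnc3c(NCc4ccc(F)c(Cl)c4)ncnc32)[C@H](O)[C@@H]1O` is the next compound. It differs from compound 3 in one place:

3-chloro-4-fluorophenyl in place of 2-methoxyphenyl on a saturated chain carbon bound to a nitrogen on an aromatic ring

For the measured compounds named here, the three measured steps are the only comparisons that bear on this change, and none of them yields a readable size. What they do show is that swapping one ring substituent for another on the saturated chain carbon bound to a nitrogen on the shared core left every compound at the limit. The change from compound 3 to compound 4 is of the same kind, so the expectation is that the limit is reached again and that no step beyond the scatter can be read, which is what a step that the limit leaves unreadable from compound 3 to compound 4 means here. For compound 4 the expected value in this assay is 200000 nM, within the range 60000 nM to 600000 nM, most probably reported as a limit only.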

Compound 4, half-maximal inhibitory concentration: 167000 nM
For compound 4 the middle estimate is 1.2-fold (0.08 log units) above the measured one, and the stated range covers the measured number.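

In this assay compound 4 gives 167000 nM. No step from compound 1, compound 2 or compound 3 to compound 4 can be read, because those three compounds each stand only at a limit: the limit of > 166000 nM in this assay, at which 3 of the 4 values shown sit.

The compounds shown leave open whether any group at this place on the shared core gives a clearly stronger inhibitor.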